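Fluorine Added to the Benzamide of a Cytosine Congener

The compounds below may be only part of what the source reports. "The series", "measured", "known", "first", "only" and "open" are said of these compounds alone.

compound 1 `Nc1ccn(C/C=C\CNC(=O)c2ccccc2)c(=O)n1`: > 100000 nM, a limit of the assay
compound 2 `O=C(NC/C=C\Cn1ccc(=O)[nH]c1=O)c1ccc(F)cc1`: > 100000 nM, a limit of the assay

In a functional assay on HeLa cells (Homo sapiens) for cytotoxicity, read by MTT assay, with a stated time of 72 h (on this read-out higher numbers stand for weaker inhibition and lower numbers for stronger inhibition), compound 1 gives no number, only a limit of the assay. Compound 2 likewise stops at a limit. Compound 1 therefore stands at the limit of > 100000 nM in this assay, at which 2 of the 2 values shown sit. Compound 3 `Nc1ccn(C/C=C\CNC(=O)c2ccc(F)cc2)c(=O)n1` differs from compound 1 by fluoro in place of hydrogen on an aromatic carbon. Among the measured compounds shown here, no measured step joins compound 1 to compound 3, so in this assay the account expects nothing beyond the scatter, in either direction. Compound 3 is estimated at 100000 nM, between 30000 nM and 300000 nM, an expected step of a number no higher from compound 1 to compound 3 (the limit leaves the size open).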

Compound 3, half-maximal inhibitory concentration: > 100000 nM
Compound 3 was reported as a limit; the forecaster's own chance of this, stated with the estimate: 85%; the middle value lies on the limit itself.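

Among the compounds shown here, compound 3 also stops at a limit of the assay, > 100000 nM, so no step from compound 1 to compound 3 can be read. The compounds shown leave open whether going from phenyl to 4-fluorophenyl changes the read-out at all.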